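The source may report more compounds than this note shows. Statements on the series, on what has been measured and on what is new or still open speak of the compounds shown alone.

Three compounds have a number in an ADME assay on HaCaT cells (Homo sapiens) for cytotoxicity (a higher number here means a weaker inhibitor, a lower number a stronger inhibitor), so far. Compound 1 `CCCCC(Cl)CCCC[C@H](C)[C@@H](O)c1cc(O)c([C@@H](CCCC)CCCC[C@H](C)[C@@H](OC(C)=O)c2cc(O)cc(O)c2)c(O)c1` gives 25000 nM in this assay. Compound 2 `CCCCC(Cl)CCCC[C@H](C)[C@@H](OC(C)=O)c1cc(O)cc(O)c1`, the smaller of the three, gives 100000 nM, and compound 3 `CCCC[C@H]1CCCC[C@H](C)[C@@H](O)c2cc(O)c(c(O)c2)[C@@H](CCCC)CCCC[C@H](C)[C@@H](OC(C)=O)c2cc(O)c1c(O)c2`, in which a further ring closes the two arms, gives 2900 nM. On these numbers compound 1 stands second highest: compound 2 gives a higher number and compound 3 a lower one, and both gaps lie beyond the usual scatter of this assay.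

Compound 4 `CCCCC(Cl)CCCC[C@H](C)[C@@H](OC(C)=O)c1cc(O)c([C@@H](CCCC)CCCC[C@H](C)[C@@H](OC(C)=O)c2cc(O)cc(O)c2)c(O)c1` has not yet been measured. It differs from compound 1 in one place: acetyl in place of hydrogen on an oxygen on a saturated carbon. Cut one bond further out, the change reads hydroxy to acetoxy, so compound 4 carries an acetoxy group on both arms where compound 1 carries one acetoxy and one free hydroxy.

Among the compounds with values here, no measured pair here shows this exact change alone, so the size of the step can only be guessed from the spread of the three numbers. Compound 2, which carries the acetoxy but lacks the second arm, gives 100000 nM, a higher number than compound 1. A modest move toward a higher number is expected for compound 4, with the step from compound 1 a 1.3-fold higher number from compound 1 to compound 4 (0.11 log units; within the scatter) likely within or only just beyond the scatter. Compound 4 is therefore estimated at 32000 nM, within a range of 12000 nM to 80000 nM.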

Compound 4, half-maximal inhibitory concentration: 25000 nM
Compound 4: middle estimate off by 1.3-fold (0.11 log units), on the high side; measured number inside the range.
By their numbers in this assay, from the lowest: compound 3; then compounds 1 and 4 (each within the scatter of the next); then compound 2.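

In this assay, within the data shown here, placing an acetyl in place of hydrogen on an oxygen on a saturated carbon gives no change at the digits printed from compound 1 to compound 4 (within the scatter), which is the first step in this set that can be read at a single place. The earlier compounds shown here differ from one another in more than one place, so they could not show what this hydroxy-to-acetoxy change does alone; here, in the setting of compound 1, a free hydroxy and an acetoxy at this position cannot be told apart by this read-out. Nothing measured here offers an explanation for this result.

The compounds shown leave open whether other groups on this oxygen, such as a longer chain in place of the acetyl, or an amine or a carboxylic acid in place of the hydroxy, would also leave the number in the same place. They also leave open whether the same hydroxy-to-acetoxy change on compound 3, in which a further ring closes the two arms, would give a similarly flat result.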